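A few compounds are considered here, and "the series" means these few. Any claim that something is new, unique, unknown or untested is made for them only; others in the source may bear on it.

In an ADME assay on HepG2 cells (Homo sapiens) for inhibition, read by resazurin assay, with a stated time of 48 h (on this read-out higher numbers stand for an effect only at larger amounts of compound and lower numbers for an effect already at smaller amounts), compound 2 `O=C(Nc1ccc2sc(-c3ccc(F)c(F)c3)nc2c1)N1CCCC1` gives > 50 uM, which is a limit of the assay and not a number. Compound 1 `O=C(Nc1ccc2sc(-c3ccc(F)c(F)c3)nc2c1)N1CCC(F)CC1` gives > 50 uM, also a limit. Compound 3 `O=C(Nc1ccc2sc(-c3ccc(F)c(F)c3)nc2c1)N1CCCCC1` gives > 50 uM, again a limit. Within the data shown here, compound 2 thus has no number of its own, and the whole series so far rests on (the limit of > 50 uM in this assay, at which 3 of the 3 values shown sit).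

Compound 4 `O=C(Nc1ccc2sc(-c3ccc(F)cc3)nc2c1)N1CCCC1` departs from compound 2 by hydrogen in place of fluoro on an aromatic carbon, taking 3,4-difluorophenyl to 4-fluorophenyl.

Three measured steps are available: a step that the two limits leave unreadable from compound 1 to compound 2, a step that the two limits leave unreadable from compound 2 to compound 3 and a step that the two limits leave unreadable from compound 1 to compound 3. All three alter the group on the carbonyl carbon, none alters the 3,4-difluorophenyl group, and none has a readable size. They therefore give no sign of a change in this assay, and the expected result is a step that the limit leaves unreadable from compound 2 to compound 4, with no size beyond the scatter and no direction. For compound 4 the estimated value is 60 uM, with an expected range from 30 uM to 120 uM.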

Compound 4, concentration for 90% of the maximal effect: > 50 uM
Compound 4: a limit, no number; the forecaster's own chance of this, stated with the estimate: 85%; the middle value lies beyond the limit too.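

In this assay compound 4 gives > 50 uM, which is a limit and not a number. Among these compounds, compound 2 also stands at a limit, so no step from compound 2 to compound 4 can be read. The compounds shown leave open whether any of these changes alters the read-out at all: the limit of > 50 uM in this assay, at which 4 of the 4 values shown sit.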